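Aryl Swap on the Piperazine Nitrogen of Compound 1

The source may hold more compounds than are shown below. What is called first, only, known or untested is meant among the compounds shown, and "the series" means these compounds.

Measured so far:
compound 1 `CCCc1nc(-c2ccccc2)c(CNCCCN2CCN(c3ccc(F)cc3)CC2)o1` — 62.5%
compound 2 `CCCc1nc(-c2ccccc2)c(CNCCN2CCN(c3ccc(F)cc3)CC2)o1` — 54.1%

Two compounds have been run in an assay on HEK293 cells for inhibition of Voltage-dependent T-type calcium channel subunit alpha-1G (Homo sapiens), read by fluorescence, tested at 10 uM; a lower number here means less inhibition, a higher number more inhibition at the concentration tested (going by the name of the read-out). Compound 1 gives 62.5%. Compound 2 gives 54.1%. Compound 1 has the higher of the two numbers, but the gap to compound 2 lies within the usual scatter, so the two cannot be told apart. For the measured compounds named here, no step between measured compounds that differ in one place is available.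

Compound 3 `CCCc1nc(-c2ccccc2)c(CNCCCN2CCN(c3cccc(C)c3)CC2)o1` differs from compound 1 in one place: 3-methylphenyl in place of 4-fluorophenyl on an amine nitrogen in a ring. Nothing in the measured pair bears on this exchange, so no step beyond the scatter is expected in this assay in either direction. Compound 3 is estimated at 58%, with a range from 38% to 78%. The expected step of a number 4.5 percentage points lower from compound 1 to compound 3 (within the scatter) is within the scatter.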

Compound 3, a percentage reported as inhibition, at one concentration (the size of the read-out at that concentration, not a potency): 47.8%
Compound 3: the middle estimate sits 10.2 percentage points above what was measured, and the stated range covers the measured number.
By their numbers in this assay, from the lowest: compounds 3, 2 and 1 (each within the scatter of the next, the first and the last beyond it).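

In this assay, for the compounds shown here, this position proved sensitive to the aryl group it carries: 3-methylphenyl in place of 4-fluorophenyl gives a number 14.7 percentage points lower from compound 1 to compound 3 (beyond the scatter), a modest step and the first between compounds that differ in one place. The two groups have the same heavy-atom count, and each is one six-membered aromatic ring of carbon only, so the step appears even though those counts stay the same. Nothing measured alongside these compounds accounts for the step.

The exchange alters both the substituent and its place on the phenyl ring, so the compounds shown cannot separate the two. Open too, from the compounds shown here alone, is how 4-methylphenyl, 3-fluorophenyl or an unsubstituted phenyl would read on this nitrogen, and whether either aryl group would give the same step with the shorter chain of compound 2.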